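Benzoyl in place of methylsulfonyl on an amine nitrogen

The source may report more compounds than this note shows. Statements on the series, on what has been measured and on what is new or still open speak of the compounds shown alone.

Within the data shown here, in an ADME assay on Vero cells (Chlorocebus sabaeus) for cytotoxicity, read by MTT assay, with a stated time of 48 h (on this read-out higher numbers stand for weaker inhibition and lower numbers for stronger inhibition), compound 2 `CS(=O)(=O)NC1CCC(CN2CCN(c3cc(=O)c4cc(C(F)(F)F)cc([N+](=O)[O-])c4s3)CC2)CC1` gives 48.5 ug/mL, the only actual number so far. Compound 1 `O=C(OC1CCC(CN2CCN(c3cc(=O)c4cc(C(F)(F)F)cc([N+](=O)[O-])c4s3)CC2)CC1)c1ccccc1` gives > 64 ug/mL, which is a limit of the assay. Compound 3 `O=C(NC1CCC(CN2CCN(c3cc(=O)c4cc(C(F)(F)F)cc([N+](=O)[O-])c4s3)CC2)CC1)c1ccccc1` carries benzoyl in place of methylsulfonyl on an amine nitrogen. Among the measured compounds shown here, one measured step bears on this change, methanesulfonamido in place of benzoyloxy, and it is small: an at least 1.3-fold lower number from compound 1 to compound 2 (0.12 log units; that floor lies within the scatter). The expected change is a 1.2-fold higher number from compound 2 to compound 3 (0.09 log units; within the scatter), with no step beyond the scatter expected in this assay. Compound 3 is estimated at 60 ug/mL, with an expected range of 28 ug/mL to 120 ug/mL.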

Compound 3, half-maximal inhibitory concentration: 44.3 ug/mL
Estimate against measurement, compound 3: 1.4-fold (0.13 log units) above, within the range that was stated.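

In this assay, among these compounds, the change on the amine nitrogen gives the first step between two actual numbers: a 1.1-fold lower number from compound 2 to compound 3 (0.04 log units; within the scatter), so methylsulfonyl and benzoyl, with its six-membered aromatic ring, are not told apart at this position. Benzamido in place of benzoyloxy reads an at least 1.4-fold lower number from compound 1 to compound 3 (0.15 log units; that floor lies within the scatter). That step is only a floor, as compound 1 stands at a limit of the assay: the limit of > 64 ug/mL in this assay, at which 1 of the 3 values shown sits.

Open, on these data alone, is whether a free amine or a carboxylic acid in this place would give a step beyond the scatter.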